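Adding a methoxy group to compound 2

The source may report more compounds than this note shows. Statements on the series, on what has been measured and on what is new or still open speak of the compounds shown alone.

Of the compounds shown here, two sharing one core have been measured in an assay on CHO cells for positive allosteric modulation of adenosine receptor A1 (Homo sapiens), read by ERK phosphorylation, tested at 10 uM; a higher number here means a weaker effect of the compound at the concentration tested, a lower number a stronger effect. Compound 1 `COc1ccc(-c2cc(C(=O)c3ccccc3)c(N)s2)cc1` gives 14%. Compound 2 `Nc1sc(-c2ccccc2)cc1C(=O)c1ccc(Cl)cc1` gives 16% in this assay, and the two numbers lie within the usual scatter of each other, so neither can be called the stronger. The next compound, compound 3 `COc1ccc(-c2cc(C(=O)c3ccc(Cl)cc3)c(N)s2)cc1`, differs from compound 2 in one place: methoxy in place of hydrogen on an aromatic carbon. With compound 1 at 14% already carrying that methoxy on a similar core, no step beyond the scatter is expected in this assay. Compound 3 is expected to give about 15%, within 4% to 28%. The expected step of a number 1 percentage points lower from compound 2 to compound 3 (within the scatter) is therefore small.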

Compound 3, a percentage reported as activity, at one concentration (the size of the read-out at that concentration, not a potency): 29%
The estimate for compound 3 lay 14 percentage points below the measured number, and the stated range ends below it.
By their numbers in this assay, from the lowest: compounds 1 and 2 (each within the scatter of the next); then compound 3.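

In this assay, methoxy in place of hydrogen on an aromatic carbon, para to a large group, weakens the effect when the chloro group is present (a number 13 percentage points higher from compound 2 to compound 3 (beyond the scatter)). Chloro in place of hydrogen likewise weakens it when the methoxy is present (a number 15 percentage points higher from compound 1 to compound 3 (beyond the scatter)), so compound 3, which carries both groups, reads weaker than compound 1 or compound 2, which each carry one. Nothing available explains this shift. From the compounds shown here alone, whether ethoxy or an amine at the methoxy position would give a similar number remains open.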